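Inverting One Stereocentre From Compound 3 to Compound 4

The source may hold more compounds than are shown below. What is called first, only, known or untested is meant among the compounds shown, and "the series" means these compounds.

In an ADME assay on S9 fraction from liver (Mus musculus, strain CD-1) for metabolic stability, read by LC-MS, using NADPH, with stated times of 5 min and 60 min, tested at 5 uM (a lower number here means that less of the compound is left, a higher number that more of the compound is left), compound 1 `COc1cc(C2CN(C(=O)c3cc(OCCO)ccn3)C2)ccc1OCc1ccc(C2CC2)cc1` gives 64% and compound 2 `COc1ccc(COc2ccc(C3CN(C(=O)c4cc(OCCO)ccn4)C3)cc2OC)cc1` gives 48% while compound 3 `COc1cc(C2CN(C(=O)c3cc(OC[C@H](O)CO)ccn3)C2)ccc1OCc1ccc(C2CC2)cc1` gives 67% and so stands level with compound 1 within the scatter and apart from compound 2 beyond it. Compound 4 `COc1cc(C2CN(C(=O)c3cc(OC[C@@H](O)CO)ccn3)C2)ccc1OCc1ccc(C2CC2)cc1` departs from compound 3 as follows: the two compounds have the same atoms and bonds and differ only in configuration as drawn: 1 of 1 stereo elements differ; a stereocentre at a saturated chain carbon is drawn R in compound 3 and S in compound 4 and nothing else separates them. Neither measured step alters configuration. Adding the hydroxymethyl on that chain gave a number 3 percentage points higher from compound 1 to compound 3 (within the scatter) and methoxy in place of cyclopropyl on an aromatic carbon gave a number 16 percentage points lower from compound 1 to compound 2 (beyond the scatter) in a different part of the structure. In this assay no step beyond the scatter is therefore expected. The estimated step is a number 2 percentage points lower from compound 3 to compound 4 (within the scatter) and no more. For compound 4 the expected value is 65% with an estimated range from 53% to 77% as its upper end.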

Compound 4, percent of the compound remaining: 68%
For compound 4 the middle estimate is 3 percentage points below the measured one; measured number inside the range.
By their numbers in this assay, from the lowest: compound 2; then compounds 1, 3 and 4 (each within the scatter of the next).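

In this assay, both drawn forms of the stereocentre at the saturated chain carbon can now be read, and inverting it gives a number 1 percentage points higher from compound 3 to compound 4 (within the scatter). Adding the hydroxymethyl in this second configuration likewise gives a number 4 percentage points higher from compound 1 to compound 4 (within the scatter), so neither form separates from the compound without that group. The comparison speaks to configuration alone: the fact that compounds 3 and 4 differ only in the configuration as drawn

The compounds leave open whether an amine or a carboxylic acid in place of the hydroxymethyl would stay level with these compounds. They also leave open whether configuration stays without consequence when methoxy replaces cyclopropyl.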